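A few compounds are considered here, and "the series" means these few. Any claim that something is new, unique, unknown or untested is made for them only; others in the source may bear on it.

Of the compounds shown here, three sharing one core have so far been measured in a physicochemical assay for permeability; on this read-out higher numbers stand for higher permeability and lower numbers for lower permeability. Compound 1 `CCNC1=NCCC2(CCCCC2)S1` gives 8.78 10^-6 cm/s, compound 2 `FC(F)(F)c1ccc(NC2=NCCC3(CCCCC3)S2)cc1` gives 3.06 10^-6 cm/s, and compound 3 `Cc1cccc(C(C)C)c1NC1=NCCC2(CCCCC2)S1` gives 9.04 10^-6 cm/s. Compound 2 stands lowest of the three: compound 1 and compound 3 both sit higher, and each of those gaps is beyond the usual scatter of this assay.

Compound 4 `CC(C)c1ccc(NC2=NCCC3(CCCCC3)S2)cc1` has not yet been measured. It differs from compound 2 in one place: isopropyl in place of trifluoromethyl on an aromatic carbon. For the measured compounds named here, no pair of measured compounds differs by exactly this change, so the expectation rests on the wider picture. Compound 3, which also carries an isopropyl on an aromatic carbon and no trifluoromethyl, gives 9.04 10^-6 cm/s, one of the two higher numbers. On that basis the step is expected to go upward, beyond the scatter, by about a 2.3-fold higher number from compound 2 to compound 4 (0.36 log units; beyond the scatter). Compound 4 is therefore estimated to give roughly 7 10^-6 cm/s in this assay, within a range from 3.5 10^-6 cm/s to 14 10^-6 cm/s.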

Compound 4, apparent permeability: 15.7 10^-6 cm/s
Compound 4: middle estimate off by 2.2-fold (0.35 log units), on the low side; the measured number lies above the stated range.
By their numbers in this assay, from the lowest: compound 2; then compounds 1, 3 and 4 (each within the scatter of the next).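

In this assay, putting isopropyl in place of trifluoromethyl on an aromatic carbon, para to a large group, gives a 5.1-fold higher number from compound 2 to compound 4 (0.71 log units; beyond the scatter). For the compounds shown here, this is the first pair in the set that differs in one place only, so a change in the number can now be tied to this single position, even though the groups are close by count, with 4 heavy atoms leaving and 3 entering, and neither carries a hydrogen-bond donor or acceptor. Nothing measured here gives a reason for the size of this step.

Going by these compounds, the result rests on one pair, so it is open whether the same exchange would act alike elsewhere on the aromatic ring. On these data alone, it is also open how other groups at this position, such as an amine, a carboxylic acid or a longer chain, would compare.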